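The source may hold more compounds than are shown below. What is called first, only, known or untested is meant among the compounds shown, and "the series" means these compounds.

Of the compounds shown here, two built on the same core have so far been tested in a functional assay on MGC-803 cells (Homo sapiens) for inhibition, read by sulforhodamine B assay; a lower number here means a stronger inhibitor, a higher number a weaker inhibitor. Compound 1 `O=C1C=C(N2CCC2)C(=O)c2c1nc1n2[C@H]2OC[C@@H](O)[C@H]2OC1` returns no number in this assay but only a limit, > 16000 nM. Of the two values shown, one therefore sits at the limit of > 16000 nM in this assay, at which 1 of the 2 values shown sits. For the measured compounds named here, compound 2 `O=C1C=C(Nc2ccc(C(F)(F)F)cc2)C(=O)c2c1nc1n2[C@H]2OC[C@@H](O)[C@H]2OC1` is the single compound with a numerical result, giving 2820 nM in this assay, so it stands as the only measured point from which the next compound can be judged.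

Compound 3 `COc1cccc(NC2=CC(=O)c3nc4n(c3C2=O)[C@H]2OC[C@@H](O)[C@H]2OC4)c1` differs from compound 2 in one place: 3-methoxyphenyl in place of 4-(trifluoromethyl)phenyl on an amine nitrogen. Going by the values given here, no pair of measured compounds shows the effect of a change of this kind, so the direction of the step is not fixed by the data. With only compound 2 as a reference, the step from compound 2 to compound 3 is expected to be modest, a 1.2-fold higher number from compound 2 to compound 3 (0.09 log units; within the scatter), and not to exceed the usual scatter by a large margin. On that basis compound 3 is estimated to give 3500 nM in this assay, within a range from 1200 nM to 12000 nM.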

Compound 3, half-maximal inhibitory concentration: 1780 nM
Compound 3: middle estimate off by 2.0-fold (0.29 log units), on the high side; the measured number falls inside the stated range.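

In this assay, the exchange on the amine nitrogen gives a 1.6-fold lower number from compound 2 to compound 3 (0.20 log units; within the scatter), so the two aryl groups, 3-methoxyphenyl and 4-(trifluoromethyl)phenyl, cannot be told apart at this position, although one brings a hydrogen-bond acceptor that the other lacks. For the compounds shown here, the same compound also gives the first comparison that clears the scatter, with (3-methoxyphenyl)amino in place of azetidin-1-yl on a double-bonded ring carbon giving an at least 8.9-fold lower number from compound 1 to compound 3 (0.95 log units; beyond the scatter). The figure for compound 1 is a limit and not a number, so this step has no fixed size: the limit of > 16000 nM in this assay, at which 1 of the 3 values shown sits.

What the compounds shown leave open is which part of the change from azetidin-1-yl carries this difference, since compound 3 differs from compound 1 in the whole group on that carbon, and neither a plain phenyl group, a benzyl group nor an open alkyl chain on the amine nitrogen appears among them. Compound 2 and compound 3 also differ in both the substituent and its place on the aryl ring, so the effect of each alone cannot be read.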